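Sulfonyl substituent swap from compound 2 to compound 3

The compounds below may be only part of what the source reports. "The series", "measured", "known", "first", "only" and "open" are said of these compounds alone.

Compound 2 `COc1ccc(S(=O)(=O)c2n[nH]c3ccc(N4CCN(C)CC4)cc23)cc1` stands highest of the two numbers in a functional assay on HeLa cells for antagonist activity at 5-hydroxytryptamine receptor 6 (Homo sapiens) (a higher number here means a weaker inhibitor, a lower number a stronger inhibitor), where compound 2 gives 544 nM. Compound 1 `CN1CCN(c2ccc3[nH]nc(S(=O)(=O)c4ccc(Cl)cc4)c3c2)CC1` gives 108 nM in this assay; the step of a 5.0-fold higher number from compound 1 to compound 2 (0.70 log units; beyond the scatter) covers methoxy in place of chloro on an aromatic carbon. Compound 3 `CN1CCN(c2ccc3[nH]nc(S(=O)(=O)c4cccs4)c3c2)CC1` carries a different change: thiophen-2-yl in place of 4-methoxyphenyl on a sulfonyl sulfur. Within the data shown here, no measured step covers thiophen-2-yl entering in place of 4-methoxyphenyl; the only bearing is that loss of the methoxy group may undo part of a 5.0-fold higher number from compound 1 to compound 2 (0.70 log units; beyond the scatter). For compound 3 a modest drop in the number is expected, a 2.5-fold lower number from compound 2 to compound 3 (0.39 log units; beyond the scatter), with wide uncertainty. Compound 3 is estimated at 220 nM, between 70 nM and 700 nM.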

Compound 3, half-maximal inhibitory concentration: 331 nM
Compound 3: middle estimate off by 1.5-fold (0.18 log units), on the low side; the measured number falls inside the stated range.
By their numbers in this assay, from the lowest: compound 1; then compounds 3 and 2 (each within the scatter of the next).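

In this assay, thiophen-2-yl in place of 4-methoxyphenyl on a sulfonyl sulfur gives a step within the scatter (a 1.6-fold lower number from compound 2 to compound 3 (0.22 log units; within the scatter)), so these two groups are not separated at this position. Thiophen-2-yl in place of 4-chlorophenyl gives a step beyond the scatter (a 3.1-fold higher number from compound 1 to compound 3 (0.49 log units; beyond the scatter)), leaving compound 1, with its 4-chlorophenyl, the strongest inhibitor of the three. No measured evidence bears on the reason for either step.

Open, as far as these compounds go, is where unsubstituted phenyl, 4-aminophenyl or 4-carboxyphenyl would stand on the sulfonyl sulfur, and whether a chloro group on the thiophen-2-yl ring would lower the number.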